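Methoxy for Trifluoromethyl on the Benzyl Triazole

This account rests on a few compounds, and the source may have more. Where it says the series, first, only, none or still open, it means among the compounds named here.

Of the compounds shown here, two sharing one core have been tested in a functional assay on PC-3 cells (Homo sapiens) for inhibition, read by MTT assay, with a stated time of 72 h; a lower number here means a stronger inhibitor, a higher number a weaker inhibitor. Compound 1, `CC(C)n1ncc2c(C(=O)NCc3cn(-c4ccccc4F)nn3)cccc21`, returns only a limit of the assay: in this assay compound 1 gives > 40000 nM, and this is a limit rather than a number. Within the data shown here, compound 2, `CC(C)n1ncc2c(C(=O)NCc3cn(Cc4ccc(C(F)(F)F)cc4)nn3)cccc21`, gives the only numerical reading in this set: in this assay compound 2 gives 23900 nM. Where compound 2 stands is therefore simple to state: it is the single measured number shown, and the other entry sits at the assay limit, as noted in the limit of > 40000 nM in this assay, at which 1 of the 2 values shown sits.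

Compound 3, `COc1ccc(Cn2cc(CNC(=O)c3cccc4c3cnn4C(C)C)nn2)cc1`, has not yet been measured. It differs from compound 2 in one place: methoxy in place of trifluoromethyl on an aromatic carbon. Among the measured compounds shown here, no measured step of this kind exists among the compounds here, so there is no direct precedent to draw on. The expected step in this assay from compound 2 to compound 3 is a 1.0-fold higher number from compound 2 to compound 3 (0.02 log units; within the scatter), which is estimated to fall within the usual scatter of the assay rather than beyond it. On that basis compound 3 is expected to give about 25000 nM in this assay, with a range estimated from 8000 nM to 60000 nM.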

Compound 3, half-maximal inhibitory concentration: 34000 nM
The estimate for compound 3 lay 1.4-fold (0.13 log units) below the measured number, and the stated range covers the measured number.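

In this assay, among these compounds, methoxy in place of trifluoromethyl on an aromatic carbon, para to a large group, gives a 1.4-fold higher number from compound 2 to compound 3 (0.15 log units; within the scatter), so this is the first measured step at this position and the assay does not tell the two groups apart, although the entering methoxy carries a hydrogen-bond acceptor and the leaving trifluoromethyl carries none. The comparison with the earlier compound, 4-methoxybenzyl in place of 2-fluorophenyl on an aromatic nitrogen, gives an at least 1.1-fold lower number from compound 1 to compound 3 (0.07 log units; that floor lies within the scatter), so this change also shows no difference that can be told from the scatter. Compound 1 gives only a limit of the assay and not a number, so that step has no upper bound: the limit of > 40000 nM in this assay, at which 1 of the 3 values shown sits.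

Going by these compounds, whether an amine or a carboxylic acid on the same aromatic carbon would move the number beyond the scatter remains open. Also open, on these data alone, is what a longer chain in place of the benzyl link would do in this assay.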